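A few compounds are considered here, and "the series" means these few. Any claim that something is new, unique, unknown or untested is made for them only; others in the source may bear on it.

Compound 1, `COc1ccc(-c2nnc(NC(=O)/C=C/c3ccc(C)cc3)s2)cc1`, gives 0.58 ug/mL in a functional assay on A549 cells (Homo sapiens) for antiproliferative activity, read by MTT assay, with a stated time of 48 h; a higher number here means a weaker inhibitor, a lower number a stronger inhibitor. Compound 2, `Cc1ccc(/C=C/C(=O)Nc2nnc(-c3ccc(Br)cc3)s2)cc1`, gives 1.51 ug/mL in this assay, and compound 3, `COc1ccc(/C=C/C(=O)Nc2nnc(-c3ccc(OC)cc3)s2)cc1`, gives 0.52 ug/mL. The change from compound 1 to compound 2 is bromo in place of methoxy on an aromatic carbon, and it made a 2.6-fold higher number from compound 1 to compound 2 (0.42 log units; beyond the scatter). The cores of compound 1 and compound 3 differ by methoxy in place of methyl on an aromatic carbon, which made a 1.1-fold lower number from compound 1 to compound 3 (0.05 log units; within the scatter). Compound 4, `COc1ccc(/C=C/C(=O)Nc2nnc(-c3ccc(Br)cc3)s2)cc1`, has not yet been measured; it differs from compound 3 by bromo in place of methoxy on an aromatic carbon, the same change as that from compound 1 to compound 2. Within the data shown here, the step from compound 3 to compound 4 is expected to be a 2.5-fold higher number from compound 3 to compound 4 (0.40 log units; beyond the scatter), resting on the only earlier example of this change, which made a 2.6-fold higher number from compound 1 to compound 2 (0.42 log units; beyond the scatter) in compound 1. On that basis compound 4 is estimated to give 1.3 ug/mL in this assay, expected between 0.7 ug/mL and 2.6 ug/mL.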

Compound 4, half-maximal inhibitory concentration: 1.04 ug/mL
Beside the measured number, compound 4's estimate is 1.3-fold (0.10 log units) above it; the range from low to high includes it.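

In this assay, bromo in place of methoxy on an aromatic carbon gave a 2.0-fold higher number from compound 3 to compound 4 (0.30 log units; within the scatter), and this step agrees with the earlier one: the same change on two cores in this assay, a 2.6-fold higher number (0.42 log units; beyond the scatter) from compound 1 to compound 2 and a 2.0-fold higher number (0.30 log units; within the scatter) from compound 3 to compound 4, 1.3-fold (0.11 log units) apart, within the scatter of two such steps. Methoxy in place of methyl on an aromatic carbon gave a 1.5-fold lower number from compound 2 to compound 4 (0.16 log units; within the scatter), and this step also agrees with its earlier counterpart: the same change on two cores in this assay, a 1.1-fold lower number (0.05 log units; within the scatter) from compound 1 to compound 3 and a 1.5-fold lower number (0.16 log units; within the scatter) from compound 2 to compound 4, 1.3-fold (0.11 log units) apart, within the scatter of two such steps. Only one of the two bromo steps lies beyond the scatter and neither methoxy-for-methyl step does, so the four compounds show that each change reads alike on these two cores, not that it would do so on other cores. The compounds shown leave open what an amine, a carboxylic acid or a longer chain in place of these groups would give in this assay.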